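The compounds below may be only part of what the source reports. "The series", "measured", "known", "first", "only" and "open" are said of these compounds alone.

Compound 1 `COCCC(=O)N1CCc2c(C)c3c(n2-c2ccc(C(N)=O)c(c2)N[C@@H](C)[C@H](C)C1)CC(C)(C)CC3=O`: 54 nM
Compound 2 `CC[C@H](N)C(=O)N1CCc2c(C)c3c(n2-c2ccc(C(N)=O)c(c2)N[C@@H](C)[C@H](C)C1)CC(C)(C)CC3=O`: 45 nM

In a functional assay on U-87MG ATCC cells (Homo sapiens) for antiproliferative activity (a lower number here means a stronger inhibitor, a higher number a weaker inhibitor), compound 2 gives 45 nM. Going by the values given here, with only two numbers measured, it has a single neighbour, compound 1, and the two values lie within the usual scatter of each other, so neither can be called the better inhibitor. Compound 3 `Cc1c2c(n3c1CCN(C(=O)C1(N)CC1)C[C@@H](C)[C@H](C)Nc1cc-3ccc1C(N)=O)CC(C)(C)CC2=O` has not yet been measured. Its difference from compound 2 is 1-aminocyclopropyl in place of 1-aminopropyl on a carbonyl carbon. Put simply, 1-aminocyclopropyl stands in place of 1-aminopropyl on a carbonyl carbon, so the open chain gives way to a small ring.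

Among the compounds with values here, only one measured step bears on this change, and it concerns a group on a carbonyl carbon as well: a 1.2-fold lower number from compound 1 to compound 2 (0.08 log units; within the scatter). That exchange of groups stayed within the scatter. Within the data shown here, it is a single example, however, and no measured compound carries the three-membered ring, so the evidence is thin. No step beyond the scatter is expected, though a wide range is kept open. The expected step is no change at the digits printed from compound 2 to compound 3 (within the scatter). Compound 3 is estimated at 45 nM, with an expected range of 20 nM to 100 nM.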

Compound 3, half-maximal inhibitory concentration: 85 nM
The estimate for compound 3 lay 1.9-fold (0.28 log units) below the measured number, within the range that was stated.
By their numbers in this assay, from the lowest: compounds 2, 1 and 3 (each within the scatter of the next).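

In this assay, closing the open 1-aminopropyl chain into the three-membered ring of 1-aminocyclopropyl gives a 1.9-fold higher number from compound 2 to compound 3 (0.28 log units; within the scatter), so on this carbonyl carbon, whose other neighbour is an amide-type nitrogen in a ring, neither the new ring nor the loss of the defined stereocentre of 1-aminopropyl produces a step beyond the scatter. Exchanging 2-methoxyethyl directly for 1-aminocyclopropyl gives a 1.6-fold higher number from compound 1 to compound 3 (0.20 log units; within the scatter), which means that all three groups now seen at this place, one of them without an amine, give numbers that cannot be told apart in this assay. No measurement among those shown accounts for these numbers or tells how the three groups compare in any other respect.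

The compounds shown leave open how far this insensitivity extends, for example to a larger ring such as 1-aminocyclohexyl, a longer chain carrying a terminal amine, or a carboxylic acid at the same carbonyl carbon. They also leave open whether 1-aminopropyl with the opposite arrangement at its stereocentre would stay within the scatter of compound 2.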